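The compounds below may be only part of what the source reports. "The series", "measured", "known", "first", "only" and "open" are said of these compounds alone.

Measured compounds:
compound 1 `CCOC(=O)C(=O)C(CC)NC(=O)C(CC(C)C)NC(=O)OCc1ccccc1`: 400 nM
compound 2 `CCCCOC(=O)C(=O)C(CC)NC(=O)C(CC(C)C)NC(=O)OCc1ccccc1`: 400 nM

In an assay on isolated protein (Oryctolagus cuniculus) for inhibition of Calpain-2 catalytic subunit (Homo sapiens), at pH 8.0 (on this read-out lower numbers stand for stronger inhibition and higher numbers for weaker inhibition), compound 1 gives 400 nM and compound 2 gives 400 nM. Those two differ only in the ester chain, ethyl in place of hydrogen two bonds along the chain from an oxygen next to a carbonyl group, and that step gave no change at the digits printed from compound 1 to compound 2 (within the scatter). Compound 3 `CCOC(=O)C(=O)C(CC)NC(=O)C(CC(C)C)NC(=O)CCc1ccccc1` alters a different place: phenethyl in place of benzyloxy on a carbonyl carbon. Going by the values given here, no measured step touches that carbonyl carbon, and the one known step lay within the scatter. Compound 3 is therefore estimated at 400 nM, in the range 150 nM to 1500 nM. The expected step of no change at the digits printed from compound 1 to compound 3 (within the scatter) stays within the scatter.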

Compound 3, inhibition constant: 1200 nM
Compound 3: middle estimate off by 3.0-fold (0.48 log units), on the low side, within the range that was stated.
By their numbers in this assay, from the lowest: compounds 1 and 2 (each within the scatter of the next); then compound 3.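

In this assay, phenethyl in place of benzyloxy on the carbonyl carbon gives a 3.0-fold higher number from compound 1 to compound 3 (0.48 log units; beyond the scatter) and so moves the number beyond the scatter, whereas the ester chain step gave no change at the digits printed from compound 1 to compound 2 (within the scatter) within it. The two groups have the same count of heavy atoms and each carries one six-membered aromatic ring, so keeping the ring and size did not keep the number when the single oxygen gave way to carbon. Nothing measured here explains this rise. On these data alone, whether a longer chain such as phenylpropyl or a group holding an amine would raise or lower the number on this carbonyl carbon remains open. Also open, as far as these compounds go, is whether changing the ester chain would still leave the number level with phenethyl present.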